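From Phenyl to Thiophen-3-yl on Compound 3

This account rests on a few compounds, and the source may have more. Where it says the series, first, only, none or still open, it means among the compounds named here.

Measured in an ADME assay on MT4 cells (Homo sapiens) for cytotoxicity, read by XTT assay, with a stated time of 5 days; a lower number here means that less compound is tolerated, a higher number that more compound is tolerated:
- Compound 1 `CNC(=O)[C@@H](NC(=O)[C@](O)(CCCN(Cc1ccc(Br)cc1)NC(=O)[C@@H](NC(=O)OC)C(C)(C)C)Cc1ccccc1)C(C)(C)C`: > 10000 nM
- Compound 2 `CNC(=O)[C@@H](NC(=O)[C@@](CCCN(Cc1ccc(Br)cc1)NC(=O)[C@@H](NC(=O)OC)C(C)(C)C)(Cc1ccccc1)[Si](C)(C)C(C)(C)C)C(C)(C)C`: > 10000 nM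
- Compound 3 `CNC(=O)[C@@H](NC(=O)[C@@](O)(CCCN(Cc1ccc(-c2ccccc2)cc1)NC(=O)[C@@H](NC(=O)OC)C(C)(C)C)Cc1ccccc1)C(C)(C)C`: > 50000 nM

None of these three entries is an exact number, since each is a limit of the assay. They fall into two groups: the limit of > 10000 nM in this assay, at which 2 of the 3 values shown sit, and (the limit of > 50000 nM in this assay, at which 1 of the 3 values shown sits). Compound 3 gives > 50000 nM, and this is a limit.

Compound 4 `CNC(=O)[C@@H](NC(=O)[C@@](O)(CCCN(Cc1ccc(-c2ccsc2)cc1)NC(=O)[C@@H](NC(=O)OC)C(C)(C)C)Cc1ccccc1)C(C)(C)C` has not yet been measured. It differs from compound 3 in one place: thiophen-3-yl in place of phenyl on an aromatic carbon. In words, thiophen-3-yl stands in place of phenyl on an aromatic carbon, so that 4-phenylphenyl becomes 4-(thiophen-3-yl)phenyl.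

For the measured compounds named here, no pair of measured compounds here shows the size of a single change, so the expectation rests on compound 3 alone. One aromatic ring replaces another and no net charge enters, so no step beyond the usual scatter is expected in this assay, in either direction. The estimated change is a number no higher from compound 3 to compound 4 (the limit leaves the size open). A limit rather than an exact number is the most likely report. Compound 4 is estimated at 50000 nM, with an expected range from 15000 nM to 100000 nM.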

Compound 4, half-maximal cytotoxic concentration: > 50000 nM
Compound 4 ended at the assay's limit; the forecaster's own chance of this, stated with the estimate: 85%; the middle value lies on the limit itself.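

In this assay compound 4 gives > 50000 nM, which is a limit. Compound 3 gives > 50000 nM, also a limit. With two limits, no step can be read between compound 3 and compound 4. The compounds shown leave open the concentration at which either compound would reach the half-maximal cytotoxic effect, and whether swapping phenyl for thiophen-3-yl shifts it.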